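Trimming the amine substituent of compound 1

The compounds below may be only part of what the source reports. "The series", "measured", "known", "first", "only" and "open" are said of these compounds alone.

Compound 1, `CCN/C(SC)=C(/C#N)C(=O)Nc1ccc(OCC)cc1`: 16400 nM
Compound 2, `CCOc1ccc(-n2nnc3n[nH]c(NC)c3c2=O)cc1`: 7010 nM
Compound 3, `C=CCNc1[nH]nc(N)c1C(=O)Nc1ccc(OCC)cc1`: 22000 nM

All three compounds were tested in a functional assay on Huh-7 cells (Homo sapiens) for cytotoxicity, read by resazurin assay, with a stated time of 48 h; on this read-out higher numbers stand for weaker inhibition and lower numbers for stronger inhibition. Among these three numbers compound 1 stands second highest. Its nearest neighbour is compound 3, whose number lies within the scatter of the number for compound 1, so the two cannot be told apart on this evidence. The number for compound 2 is lower than that for compound 1, and this gap lies beyond the scatter. Compounds 2 and 3 are built on cores different from that of compound 1, so no single-point comparison between measured compounds is available.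

Compound 4, `CCOc1ccc(NC(=O)/C(C#N)=C(\NC)SC)cc1`, has not yet been measured. It differs from compound 1 in one place: hydrogen in place of methyl on a saturated chain carbon bound to an amine nitrogen. The same difference, read one bond further out, is ethyl to methyl, or ethylamino to methylamino. Among the compounds with values here, since no measured pair differing in one place exists here, nothing measured fixes the size of this step. A change of this small size is expected to give no step beyond the scatter in this assay. The expected step is a 1.0-fold lower number from compound 1 to compound 4 (0.01 log units; within the scatter). Compound 4 is therefore estimated to give 16000 nM in this assay, with a range from 7000 nM to 36000 nM.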

Compound 4, half-maximal inhibitory concentration: 5780 nM
Compound 4: middle estimate off by 2.8-fold (0.44 log units), on the high side; measured number below the stated range.
By their numbers in this assay, from the lowest: compounds 4 and 2 (each within the scatter of the next); then compounds 1 and 3 (each within the scatter of the next).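

In this assay, within the data shown here, trimming ethylamino to methylamino gives a 2.8-fold lower number from compound 1 to compound 4 (0.45 log units; beyond the scatter), the only step here between compounds that differ in one place. It shows that this chain on the amine nitrogen is not a silent position: although the change removes just one carbon and adds no ring, donor, acceptor or charge, the step is modest yet beyond the scatter, and it points towards stronger inhibition on this read-out. No supporting measurement is available to explain why the shorter chain gives the lower number.

On these data alone, with only ethylamino and methylamino to compare at this position, it remains open whether the number would keep falling with a plain amino group, which has no carbon on the nitrogen, or would rise again with a longer chain such as propylamino. A single pair also cannot show whether the same trim would give a step of similar size on a different core, such as those of compound 2 and compound 3, or whether the step reflects anything more specific than general cytotoxicity in these cells.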